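Saturating the long chain of compound 1

This account rests on a few compounds, and the source may have more. Where it says the series, first, only, none or still open, it means among the compounds named here.

Measured in a functional assay on HeLa cells (Homo sapiens) for cytotoxicity, read by XTT assay, with a stated time of 72 h; a higher number here means a weaker inhibitor, a lower number a stronger inhibitor:
- compound 1 `CCCCCCCC/C=C\CCCCCCCCOc1cc(O)c(C(C)=O)c(O)c1`: 31000 nM
- compound 2 `CCCCCCCC/C=C\CCCCCCCCOc1cc(O)c(C(C)=O)c(OCCCCCCCC/C=C\CCCCCCCC)c1`: > 100000 nM (a limit of the assay, not a number)

Among the compounds with values here, compound 1 holds the only true number so far, at 31000 nM. The other measured result, for compound 2, is only a limit.

Compound 3 `CCCCCCCCCCCCCCCCCCOc1cc(O)c(C(C)=O)c(O)c1` is the next to be read, and it keeps the core of compound 1. The change is decyl in place of dec-1-en-1-yl on a saturated chain carbon, eight bonds along the chain from an oxygen on an aromatic ring.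

Within the data shown here, no measured pair isolates this change. In this assay, no step beyond the scatter is expected, with any drift more likely toward weaker inhibition. The expected step is a 1.3-fold higher number from compound 1 to compound 3 (0.11 log units; within the scatter). The estimated value for compound 3 is 40000 nM, with an expected range of 15000 nM to 100000 nM.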

Compound 3, half-maximal inhibitory concentration: > 100000 nM
Compound 3 ended at the assay's limit; the forecaster's own chance of this, stated with the estimate: 25%; middle value at least 2.5-fold (0.39 log units) from the limit.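

In this assay, decyl in place of dec-1-en-1-yl is not a silent change at this place on the chain, which no earlier comparison could show: the step is an at least 3.2-fold higher number from compound 1 to compound 3 (0.50 log units; beyond the scatter). The two groups both hold 10 heavy atoms and differ only by the double bond. The value of compound 3, > 100000 nM, is a limit of the assay and not a number.

The true size of the step therefore stays unread, and the series has little room to show further weakening: the limit of > 100000 nM in this assay, at which 2 of the 3 values shown sit.

Going by these compounds, whether a shorter chain, or an amine or a carboxylic acid carried on the chain, would restore or improve on the number of compound 1 remains open.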